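The compounds below may be only part of what the source reports. "The series", "measured", "known", "first", "only" and "open" are said of these compounds alone.

Measured compounds:
compound 1 `CS(=O)(=O)CCCn1c(Cn2c(=O)n(C3CC3)c3ccncc32)cc2cc(Cl)ccc21` — in an ADME assay on HeLa cells (Homo sapiens) for cytotoxicity, read by ATP content, with a stated time of 3 days (a lower number here means that less compound is tolerated, a higher number that more compound is tolerated), compound 1 gives only the limit > 50000 nM.
compound 2 `N#CCCCn1c(Cn2c(=O)n(C3CC3)c3ccncc32)cc2cc(Cl)ccc21` — compound 2 likewise reaches only the limit > 50000 nM.
compound 3 `CS(=O)(=O)CCCn1c(Cn2c(=O)n(C3CC3)c3ccncc32)cc2cc(Br)ccc21` — compound 3 also stops at the limit > 50000 nM.

Compound 1 therefore stands at the upper edge of what this assay can report, and its two neighbours stand there with it; the three values coincide in the limit of > 50000 nM in this assay, at which 3 of the 3 values shown sit. The step from compound 1 to compound 2, a step that the two limits leave unreadable from compound 1 to compound 2, and the step from compound 1 to compound 3, a step that the two limits leave unreadable from compound 1 to compound 3, are both left unreadable by the limits, so neither tells how far below the limit any of the three compounds might lie.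

The unmeasured compound 4 `CC(C)(C)n1c(=O)n(Cc2cc3cc(Cl)ccc3n2CCCS(C)(=O)=O)c2cnccc21` differs from compound 1 in one place: tert-butyl in place of cyclopropyl on an aromatic nitrogen. Going by the values given here, no measured step touches the group on the aromatic nitrogen; the two known steps concern the chain substituent and the halogen, and both are unreadable. Among the compounds with values here, there is thus no measured step that bears on the change, and nothing to suggest a shift in this assay in either direction. Compound 4 is expected to behave like compound 1 and to stop at the limit as well, so the expected step from compound 1 to compound 4 is a number no higher from compound 1 to compound 4 (the limit leaves the size open), none beyond the scatter. The estimate for compound 4 in this assay is 50000 nM, with a range from 30000 nM to 100000 nM.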

Compound 4, half-maximal cytotoxic concentration: > 50000 nM
Compound 4: only a limit was reported; the forecaster's own chance of this, stated with the estimate: 85%; the middle value lies on the limit itself.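

In this assay, compound 1 and compound 4 both stop at a limit, so no step between them can be read, and all the compounds shown share that limit: the limit of > 50000 nM in this assay, at which 4 of the 4 values shown sit.

The compounds shown leave open where any of their true values lies, and whether tert-butyl in place of cyclopropyl changes the result in this assay at all.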